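Replacing methyl with acetyl in compound 3

The source may hold more compounds than are shown below. What is called first, only, known or untested is meant among the compounds shown, and "the series" means these compounds.

In a functional assay on PC-3 cells (Homo sapiens) for inhibition, read by MTT assay, with a stated time of 48 h (a higher number here means a weaker inhibitor, a lower number a stronger inhibitor), compound 3 (`COc1cc(Nc2nc(Nc3ccc(C)cc3)nnc2Cl)cc(OC)c1OC`) gives 14300 nM, level with compound 1 (`COc1ccc(Nc2nnc(Cl)c(Nc3cc(OC)c(OC)c(OC)c3)n2)cc1`) at 13500 nM, while compound 2 (`COc1cc(Nc2nnc(Cl)c(Nc3cc(OC)c(OC)c(OC)c3)n2)cc(OC)c1OC`) gives a clearly higher 34300 nM. Compound 4 (`COc1cc(Nc2nc(Nc3ccc(C(C)=O)cc3)nnc2Cl)cc(OC)c1OC`) carries acetyl in place of methyl on an aromatic carbon, para to a large group: acetyl in place of methyl on an aromatic carbon. Among the compounds with values here, the one measured step at this place, a 1.1-fold higher number from compound 1 to compound 3 (0.03 log units; within the scatter), exchanged methoxy for methyl and stayed within the scatter. Within the data shown here, no acetyl compound has yet been measured, so that step is only a loose guide. In this assay, no change beyond the scatter is expected, in either direction. The expected step is a 1.0-fold lower number from compound 3 to compound 4 (0.01 log units; within the scatter). For compound 4 the estimated value is 14000 nM, with an expected range from 6000 nM to 32000 nM.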

Compound 4, half-maximal inhibitory concentration: 38600 nM
Compound 4: middle estimate off by 2.8-fold (0.44 log units), on the low side; the whole stated range lies below it.
By their numbers in this assay, from the lowest: compounds 1 and 3 (each within the scatter of the next); then compounds 2 and 4 (each within the scatter of the next).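

In this assay the aromatic carbon para to a large group proves to be sensitive to the group it carries: acetyl in place of methyl gives a 2.7-fold higher number from compound 3 to compound 4 (0.43 log units; beyond the scatter) and acetyl in place of methoxy gives a 2.9-fold higher number from compound 1 to compound 4 (0.46 log units; beyond the scatter) as well. Methyl and methoxy had stayed level here, so acetyl is the first change at this place to yield a weaker inhibitor. No measurement at hand accounts for this shift. As far as these compounds go, whether an amine, a carboxylic acid or a longer chain here would track acetyl or methyl remains open.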